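The source may report more compounds than this note shows. Statements on the series, on what has been measured and on what is new or still open speak of the compounds shown alone.

Measured in a physicochemical assay for lipophilicity, at pH 7.4; on this read-out higher numbers stand for higher lipophilicity and lower numbers for lower lipophilicity:
- compound 1 `CC1(CS(C)(=O)=O)CN(c2cc(COc3ccc(F)c(F)c3F)nc(-c3ccccn3)n2)C1`: 2.9
- compound 2 `Fc1ccc(OCc2cc(OCC(F)(F)F)nc(-c3ccccn3)n2)c(F)c1F`: > 4.9, a limit of the assay and not a number
- compound 3 `CC1(COc2cc(COc3ccc(F)c(F)c3F)nc(-c3ccccn3)n2)COC1`: 4

Of the two values that are true numbers, compound 3 holds the higher, with the step of a number 1.10 log units higher from compound 1 to compound 3 (beyond the scatter). The next compound, compound 4 `COC1(COc2cc(COc3ccc(F)c(F)c3F)nc(-c3ccccn3)n2)COC1`, is unmeasured. The change is methoxy in place of methyl on a saturated ring carbon, on a saturated ring carbon, two ring bonds from the ring oxygen. Going by the values given here, two measured steps touch this side chain: a number 1.10 log units higher from compound 1 to compound 3 (beyond the scatter) and a number at least 0.90 log units lower from compound 2 to compound 3 (beyond the scatter). Both are large or at least modest, but both swap more of the molecule than this change does, and neither measures it directly. A smaller move towards lower numbers is therefore expected in this assay. The expected step is a number 0.40 log units lower from compound 3 to compound 4 (beyond the scatter). Compound 4 is estimated at 3.6, with an expected range of 3.1 to 4.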

Compound 4, distribution coefficient: 3.5
The estimate for compound 4 lay 0.10 log units above the measured number; low and high end bracket the measured number.
By their numbers in this assay, from the lowest: compound 1; then compound 4; then compound 3. At a limit, above all of these: compound 2.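

Methoxy in place of methyl on a saturated ring carbon, two ring bonds from the ring oxygen, now has a direct reading in this assay: a number 0.50 log units lower from compound 3 to compound 4 (beyond the scatter). With this change the side chain still reads above the azetidine of compound 1: a number 0.60 log units higher from compound 1 to compound 4 (beyond the scatter). The step of a number at least 1.40 log units lower from compound 2 to compound 4 (beyond the scatter) is only a bound, since compound 2 stands at a limit of the assay and not at a number: the limit of > 4.9 in this assay, at which 1 of the 4 values shown sits.

As far as these compounds go, how a hydroxyl, an ethoxy or a fluorine on this ring carbon would read in this assay stays open. The compounds shown also hold this change on one side chain only.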